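This account rests on a few compounds, and the source may have more. Where it says the series, first, only, none or still open, it means among the compounds named here.

Two compounds share one core and were tested in an assay on isolated protein for inhibition of phosphodiesterase 7 (Homo sapiens), read by scintillation proximity assay and cAMP accumulation, with a stated time of 1 h; on this read-out higher numbers stand for weaker inhibition and lower numbers for stronger inhibition. Compound 1 `N#Cc1ccccc1-c1ccc(CSc2nc(SCc3ccc(F)cc3)nc3ccccc23)cc1` carries a nitrile on its biaryl and two thioether arms; in this assay compound 1 gives > 100000 nM, which is a limit of the assay rather than a number. Compound 2 `COC(=O)c1ccccc1-c1ccc(CSc2nc(C(C)C)nc3ccccc23)cc1` replaces one arm with isopropyl and the nitrile with a methyl ester; in this assay compound 2 gives > 100000 nM, again only a limit. Both values therefore sit at the limit of > 100000 nM in this assay, at which 2 of the 2 values shown sit, and compound 2 cannot be placed above or below compound 1 on these numbers.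

Compound 3 `CC(C)c1nc(SCc2ccc(-c3ccccc3C(=O)O)cc2)c2ccccc2n1` differs from compound 2 by hydrogen in place of methyl on an oxygen next to a carbonyl group. For the measured compounds named here, no measured pair shows the effect of this change. The step that the limit leaves unreadable from compound 2 to compound 3 is expected to be none beyond the usual scatter. For compound 3 the estimate in this assay is 150000 nM, within 30000 nM to 1000000 nM, most likely again reported only as a limit.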

Compound 3, half-maximal inhibitory concentration: 44000 nM
For compound 3 the middle estimate is 3.4-fold (0.53 log units) above the measured one, within the range that was stated.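

Going from methoxycarbonyl to carboxy, with hydrogen in place of methyl on an oxygen next to a carbonyl group, gives an at least 2.2-fold lower number from compound 2 to compound 3 (0.35 log units; beyond the scatter) in this assay. The true size of this step cannot be read, since compound 2 gives > 100000 nM, which is a limit of the assay. For the compounds shown here, compound 3, at 44000 nM, is the first compound here with a value that is a number, which shows that the read-out responds to a change at this place.

Going by these compounds, whether the same change would lower the number with the fluorobenzyl thioether arm of compound 1 in place of isopropyl remains open. On these data alone, it is also open whether a primary amide or a tetrazole in place of the carboxy group would lower the number further.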